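The compounds below may be only part of what the source reports. "The series", "measured", "known", "first", "only" and "open" are said of these compounds alone.

Working notes on the fluoro-methoxy benzylamide series.

Three amides on two related cores have been run in an assay on isolated protein for agonist activity at melatonin receptor type 1C (Xenopus laevis), read by spectrophotometry; a lower number here means a smaller maximal response, a higher number a larger maximal response. Compound 1 `CCC(=O)NCc1cc(OC)ccc1F` gives 69% in this assay. Compound 2 `CCCC(=O)NCc1cc(OC)ccc1F` differs from compound 1 by methyl in place of hydrogen on a saturated chain carbon, two bonds along the chain from a carbonyl carbon, and in this assay compound 2 gives 43%. The step is a number 26 percentage points lower from compound 1 to compound 2 (beyond the scatter), so lengthening the acyl chain by one carbon lowers the maximal response on this core.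

Compound 3 `CCC(=O)NCc1ccc(F)c(OC)c1` is built from the same atoms as compound 1, joined differently; the difference between the two cores is not broken down here. In this assay compound 3 gives 86%, the highest of the three numbers, beyond the scatter above both compound 1 and compound 2.

Compound 4 `CCCC(=O)NCc1ccc(F)c(OC)c1` is the unmeasured partner of compound 3. It differs from compound 3 by methyl in place of hydrogen on a saturated chain carbon, two bonds along the chain from a carbonyl carbon, the same change as from compound 1 to compound 2, made at the same place. This change occurs twice among the compounds shown, once measured and once open.

The expectation for compound 4 rests on a single precedent, the step of a number 26 percentage points lower from compound 1 to compound 2 (beyond the scatter), transferred to the core of compound 3 in direction and in approximate size. The expected step is a number 26 percentage points lower from compound 3 to compound 4 (beyond the scatter). For the measured compounds named here, compound 4 is accordingly estimated to give about 60% in this assay, with a plausible span from 45% to 76%, the width reflecting that only one measured pair supports the transfer between cores.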

Compound 4, largest response reached (reported as efficacy), in percent of the reference or control that the assay uses: 75%
Beside the measured number, compound 4's estimate is 15 percentage points below it; measured number inside the range.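

Carried to the second core, methyl in place of hydrogen on a saturated chain carbon, two bonds along the chain from a carbonyl carbon, again lowers the maximal response in this assay, the step here being a number 11 percentage points lower from compound 3 to compound 4 (beyond the scatter). The direction of the change therefore carries over between the two cores, but its size does not: the same change on two cores in this assay, a number 26 percentage points lower (beyond the scatter) from compound 1 to compound 2 and a number 11 percentage points lower (beyond the scatter) from compound 3 to compound 4, 15 percentage points apart, beyond the scatter of two such steps These two matched pairs show that the size of the step depends on the core in this series, but they give no reason for the difference and no rule for predicting the size on any further core.

The compounds shown leave open whether the maximal response keeps falling with a longer chain, such as pentanoyl, on either core, and whether the shorter acetyl group or a branched chain, such as isobutyryl, would follow the same trend. For the compounds shown here, they also leave open whether the smaller step on the second core would persist across such a series of chain lengths, since each core is represented here by only one propanoyl and butanoyl pair.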